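The source may hold more compounds than are shown below. What is called first, only, known or untested is meant among the compounds shown, and "the series" means these compounds.

Working notes on a set of four compounds, three of which carry a number in an ADME assay on SH-SY5Y cells (Homo sapiens) for cytotoxicity, read by MTT assay, with a stated time of 72 h (a higher number here means a weaker inhibitor, a lower number a stronger inhibitor), and one of which does not yet.

Compound 1 `O=C(CN1CCN(C(=O)c2cccc(Cl)c2)CC1)N1CCN(CCCc2c[nH]c3ccc(F)cc23)CC1` in this assay gives 59800 nM. Compound 2 `COc1cccc(C(=O)N2CCN(CC(=O)N3CCN(CCCc4c[nH]c5ccc(F)cc45)CC3)CC2)c1` differs from compound 1 by methoxy in place of chloro on an aromatic carbon and in this assay compound 2 gives 79400 nM. Among the measured compounds shown here, the single measured instance of this change is the step of a 1.3-fold higher number from compound 1 to compound 2 (0.12 log units; within the scatter). Compound 3 `COc1ccc2[nH]cc(CCCN3CCN(C(=O)CN4CCN(C(=O)c5ccc(Cl)cc5)CC4)CC3)c2c1` is built on a core unlike that of compound 1; the difference between the two cores is not broken down here. In this assay compound 3 gives 159000 nM, the highest of the three numbers, with a gap to compound 2 within the scatter and a gap to compound 1 beyond it.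

Compound 4 `COc1ccc(C(=O)N2CCN(CC(=O)N3CCN(CCCc4c[nH]c5ccc(OC)cc45)CC3)CC2)cc1` awaits measurement. It differs from compound 3 by methoxy in place of chloro on an aromatic carbon. For the measured compounds named here, this is the same kind of change as the one from compound 1 to compound 2, though not the same: in compound 1 the exchanged group sits meta to a large group, in compound 3 it sits para to a large group, and the cores differ. The expected step is a 1.2-fold higher number from compound 3 to compound 4 (0.08 log units; within the scatter) because a 1.3-fold higher number from compound 1 to compound 2 (0.12 log units; within the scatter) stayed within the scatter. Compound 4 is therefore estimated at 190000 nM in this assay, with an expected range from 90000 nM to 400000 nM.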

Compound 4, half-maximal inhibitory concentration: 190000 nM
Compound 4: the middle estimate sits on the measured number at the digits printed; the range from low to high includes it.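

In this assay, methoxy in place of chloro on an aromatic carbon, here para to a large group, gives a 1.2-fold higher number from compound 3 to compound 4 (0.08 log units; within the scatter), and the 4-chlorophenyl to 4-methoxyphenyl exchange therefore leaves the two numbers indistinguishable on this core. Among the compounds shown here, this does not show that the exchange is without consequence on every core: only two pairs are available, they differ in where the exchanged group sits as well as in the core, and neither step is large enough to give a direction that could be trusted. What can be said is limited to these two pairs, where the change reads alike on both cores and the two steps cannot be told apart:  the same change on two cores in this assay, a 1.3-fold higher number (0.12 log units; within the scatter) from compound 1 to compound 2 and a 1.2-fold higher number (0.08 log units; within the scatter) from compound 3 to compound 4, 1.1-fold (0.05 log units) apart, within the scatter of two such steps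

The compounds shown leave open whether the same aromatic carbon would read differently with a group other than chloro or methoxy, such as an amine, a carboxylic acid or a nitrile. Also open, on these data alone, is whether the match between the two steps would hold on a core carrying a longer chain, or on a core with a different group in place of the fluoro or methoxy that compounds 1 to 4 carry there.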